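A few compounds are considered here, and "the series" means these few. Any claim that something is new, unique, unknown or untested is made for them only; others in the source may bear on it.

Compound 1 `O=C(O)c1ccc(C(=O)/C(=C\c2ccc(Cl)c([N+](=O)[O-])c2)SCc2ccc(Cl)cc2)cc1` gives 1000 nM
Compound 2 `O=C(O)c1ccc(C(=O)/C(=C\c2ccc(Cl)c([N+](=O)[O-])c2)SCc2ccc(F)cc2)cc1` gives 1000 nM
Compound 3 `CSc1ccc(/C=C(/SCc2ccc(Cl)cc2)C(=O)c2ccc(C(=O)O)cc2)cc1` is not yet measured

In a functional assay on DU-145 cells (Homo sapiens) for inhibition, read by trypan blue exclusion, with a stated time of 96 h (a lower number here means a stronger inhibitor of growth, a higher number a weaker inhibitor of growth), compound 1 gives 1000 nM and stands level with compound 2 at 1000 nM as the only other measured point. Among the compounds with values here, the single measured step is no change at the digits printed from compound 1 to compound 2 (within the scatter) and it leaves the 4-chloro-3-nitrophenyl group in place. Within the data shown here, the change here is 4-(methylsulfanyl)phenyl in place of 4-chloro-3-nitrophenyl on a double-bonded chain carbon bound to a double-bonded chain carbon and no measured step covers it, so the data favour no direction. In this assay no step beyond the scatter is expected, though with wide uncertainty. The expected step is no change at the digits printed from compound 1 to compound 3 (within the scatter) on this estimate. For compound 3 the estimated value is 1000 nM with an expected range from 300 nM to 3500 nM as a working figure.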

Compound 3, concentration for 50% growth inhibition: > 100000 nM
Compound 3 ended at the assay's limit (the forecaster's own chance of this, stated with the estimate: 10%); at least 100-fold (2.00 log units) between middle value and limit.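

In this assay, this position is sensitive to the group it carries: 4-(methylsulfanyl)phenyl in place of 4-chloro-3-nitrophenyl gives an at least 100-fold higher number from compound 1 to compound 3 (2.00 log units; beyond the scatter). Within the data shown here, the earlier step left this position untouched, so this is the first sign of a large effect. Compound 3 gives > 100000 nM, which is a limit and not a number, so the true size of the step stays unknown: the limit of > 100000 nM in this assay, at which 1 of the 3 values shown sits.

As far as these compounds go, the swap changes several atoms at once, so which part of it carries the loss stays open. From the compounds shown here alone, whether a 4-chlorophenyl or 3-nitrophenyl group alone would hold the level of compound 1 is also open.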